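The compounds below may be only part of what the source reports. "The series", "measured", "known", "first", "only" and "open" are said of these compounds alone.

Of the compounds shown here, two have been tested so far in an assay on HEK293 cells for inhibition of protein deacetylase HDAC6 (Homo sapiens); a lower number here means a stronger inhibitor, a higher number a weaker inhibitor. Compound 1, with the structure `CCOC(=O)SCC(=O)c1ccc(OC)cc1`, gives 5360 nM in this assay, the higher of the two numbers recorded, which marks it as the weaker inhibitor of the pair. Compound 2, with the structure `CCSC(=S)SCC(=O)c1ccc(S(=O)(=O)Nc2ccc(Cl)cc2)cc1`, gives 340 nM in this assay, a lower number that lies beyond the usual scatter of the method. Compound 2 differs from compound 1 in more than one place, so the gap between them cannot be tied to a single change.

Compound 3, with the structure `CCNC(=O)SCC(=O)c1ccc(OC)cc1`, has not yet been measured. It differs from compound 1 in one place: ethylamino in place of ethoxy on a carbonyl carbon. Among the compounds with values here, no measured pair with this same change is available, so there is nothing to show how such a swap has behaved before. On that basis the step is expected to be small, with neither direction favoured and no difference beyond the scatter: the estimated step is a 1.1-fold lower number from compound 1 to compound 3 (0.03 log units; within the scatter). Compound 3 is therefore expected to give about 5000 nM in this assay, with a likely range from 1800 nM to 14000 nM.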

Compound 3, half-maximal inhibitory concentration: 132 nM
The estimate for compound 3 lay 38-fold (1.58 log units) above the measured number, and the stated range ends above it.
By their numbers in this assay, from the lowest: compound 3; then compound 2; then compound 1.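

In this assay, putting ethylamino in place of ethoxy on a carbonyl carbon whose other neighbour is sulfur gives a 41-fold lower number from compound 1 to compound 3 (1.61 log units; beyond the scatter), the first sign that this place on the molecule can strongly affect the number, and that a swap of this kind is not automatically a small one. The two groups match in their count of heavy atoms and neither has a ring or a net charge, so the difference lies in nitrogen entering where oxygen leaves, with a hydrogen-bond donor arriving and a hydrogen-bond acceptor departing. Nothing available explains how this difference produces so large a step, and a single pair cannot separate the role of the nitrogen itself from that of the hydrogen it carries.

The compounds shown leave open whether a dimethylamino group, whose nitrogen bears no hydrogen, would keep the gain, and how a longer chain such as propylamino or butylamino would compare with ethylamino. They also leave open whether this same swap gives a step of similar size on a different core, as only one such pair is shown.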